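Carboxymethyl in place of carboxy on compound 2

The source may hold more compounds than are shown below. What is called first, only, known or untested is meant among the compounds shown, and "the series" means these compounds.

In a functional assay on aorta (Rattus norvegicus, strain Wistar) for inhibition, with a stated time of 30 min (a higher number here means that more compound is needed for the effect, a lower number that less compound is needed), compound 2 `O=C(O)CCCCCO[N+](=O)[O-]` sits at 8300 nM as the highest of the three numbers. Compound 1 `O=C(O)c1ccc(CCCO[N+](=O)[O-])cc1` at 510 nM is the nearest and compound 3 `CC(=O)Oc1ccccc1C(=O)OC(C)OC(=O)c1ccc(SCCCO[N+](=O)[O-])cc1` at 140 nM is the furthest, both lower by more than the scatter. Relative to compound 2, compound 4 `O=C(O)CCCCCCO[N+](=O)[O-]` has carboxymethyl in place of carboxy on a saturated chain carbon (carboxymethyl in place of carboxy on a saturated chain carbon, five bonds along the chain from an oxygen on an unsaturated carbon). Within the data shown here, no measured pair shows a change of this kind, and the expectation rests on compound 2 at 8300 nM alone. The expected step of a 1.3-fold lower number from compound 2 to compound 4 (0.11 log units; within the scatter) is toward a slightly lower number and stays within the scatter. Compound 4 is estimated at 6500 nM with 2500 nM to 16000 nM as the expected range.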

Compound 4, half-maximal effective concentration: 20000 nM
Compound 4: middle estimate off by 3.1-fold (0.49 log units), on the low side; measured number outside the range, above it.
By their numbers in this assay, from the lowest: compound 3; then compound 1; then compound 2; then compound 4.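

In this assay the change from carboxy to carboxymethyl on this saturated chain carbon gives the first step measured in the series, a 2.4-fold higher number from compound 2 to compound 4 (0.38 log units; beyond the scatter), modest but beyond the scatter. This position therefore responds to the change, and the number moves upward rather than staying level. No measurement shown accounts for the direction of this step.

A single pair cannot show whether a longer chain would raise the number further. Also open, going by these compounds, is how an amine in place of carboxy on this saturated chain carbon would read.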